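This account rests on a few compounds, and the source may have more. Where it says the series, first, only, none or still open, it means among the compounds named here.

Compound 1 is `COc1cc(/C=N/NC(=O)COc2cccc3ccccc23)cc(OC)c1OC`. In an ADME assay on HEL cells (Homo sapiens) for cytotoxicity (a lower number here means that less compound is tolerated, a higher number that more compound is tolerated), compound 1 reaches only a limit, >= 20 ug/mL.
Compound 2 is `COc1ccc(/C=N/NC(=O)COc2cccc3ccccc23)cc1OC`. In this assay compound 2 likewise reaches only a limit, >= 20 ug/mL.
Compound 3 is `Cc1ccc(/C=N/NC(=O)COc2cccc3ccccc23)cc1`. In this assay compound 3 gives 20 ug/mL.

Within the data shown here, compound 3 is thus the one compound here with an actual number; the other two sit at the limit of >= 20 ug/mL in this assay, at which 2 of the 3 values shown sit. Among the measured compounds shown here, the single change between measured compounds, from compound 1 to compound 2, is a step that the two limits leave unreadable from compound 1 to compound 2, so it says nothing about how large any effect might be.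

Compound 4 is `O=C(COc1cccc2ccccc12)N/N=C/c1cccc(Cl)c1`, not yet measured in this assay. It differs from compound 3 by 3-chlorophenyl in place of 4-methylphenyl on a carbon with a double bond to nitrogen. For the measured compounds named here, no measured step touches this part of the shared core; the only measured step concerns a methoxy group, and even its size cannot be read. There is therefore no ground to expect a step beyond the scatter in either direction, and the number for compound 3 is the natural anchor.

Compound 4 is expected to give about 20 ug/mL in this assay, with a range from 10 ug/mL to 40 ug/mL. The expected step from compound 3 to compound 4, no change at the digits printed from compound 3 to compound 4 (within the scatter), stays within the scatter, and the result may well again come out only as a limit.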

Compound 4, minimum cytotoxic concentration: 100 ug/mL
Compound 4: the middle estimate sits 5.0-fold (0.70 log units) below what was measured, outside the stated range (above it).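

In this assay, putting 3-chlorophenyl in place of 4-methylphenyl on a carbon with a double bond to nitrogen gives a 5.0-fold higher number from compound 3 to compound 4 (0.70 log units; beyond the scatter). Among these compounds, this is the first change whose size can be read, since the earlier step between measured compounds cannot be read, and it shows that the aromatic group at this place can shift the number beyond the usual scatter, towards more compound being tolerated by the cells. The two groups match in their count of heavy atoms and both carry no hydrogen-bond donors or acceptors, so those counts alone do not separate them, and the difference lies in which atom the ring carries and where the group's name places it.

This single step changes both the substituent and its printed ring position, so 4-chlorophenyl and 3-methylphenyl would be needed to tell whether the chlorine, the new position or the two together go with the higher number. How compound 4 stands against compound 1 and compound 2 also stays open, because those two compounds reach only a limit and not a number: the limit of >= 20 ug/mL in this assay, at which 2 of the 4 values shown sit.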